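A few compounds are considered here, and "the series" means these few. Any claim that something is new, unique, unknown or untested is made for them only; others in the source may bear on it.

Measured in a functional assay on A-375 cells (Homo sapiens) for inhibition, read by sulforhodamine B assay, with a stated time of 6 days; a higher number here means a weaker inhibitor, a lower number a stronger inhibitor:
- compound 1 `CNCCNCc1cccc(-c2nc(NC3CCOCC3)c(C)c(-c3ccnc4[nH]ccc34)n2)c1`: 18200 nM
- compound 2 `CNCCNCc1cccc(-c2nc(NC3CCOCC3)c(C)c(-c3cn(C)nc3C)n2)c1`: > 50000 nM (a limit)
- compound 3 `CNCCNCc1cccc(-c2nc(NC3CCOCC3)c(C)c(-c3c(C)nn(C)c3C)n2)c1`: > 50000 nM (a limit)

Compound 3 has no number, only the limit > 50000 nM. Compound 2 and compound 3 both sit at this ceiling, which is the limit of > 50000 nM in this assay, at which 2 of the 3 values shown sit. The step that the two limits leave unreadable from compound 2 to compound 3 therefore says nothing about the added methyl.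

Compound 4 `CNCCNCc1cccc(-c2nc(NC3CCOCC3)c(C)c(-c3cccc4cnccc34)n2)c1` replaces the 1,3,5-trimethyl-1H-pyrazol-4-yl of compound 3 with isoquinolin-5-yl: isoquinolin-5-yl in place of 1,3,5-trimethyl-1H-pyrazol-4-yl on an aromatic carbon. The new group sits on the same aromatic carbon, next to the ring nitrogen and ortho to the methyl group.

The closest evidence comes from two steps: an at least 2.7-fold higher number from compound 1 to compound 2 (0.43 log units; beyond the scatter) and an at least 2.7-fold higher number from compound 1 to compound 3 (0.43 log units; beyond the scatter). Both lead away from the two-ring group of compound 1 to a pyrazole, and both end at the ceiling. The change to compound 4 runs the other way, back to a group with two aromatic rings, although the group differs from that of compound 1. Compound 1, at 18200 nM, is the only numeric anchor, so a lower number is expected, meaning a stronger inhibitor, but only a modest one. The expected change is an at least 2.2-fold lower number from compound 3 to compound 4 (0.35 log units; beyond the scatter). For compound 4 the estimated value is 22000 nM, with an expected range of 8000 nM to 50000 nM.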

Compound 4, half-maximal inhibitory concentration: 12700 nM
The estimate for compound 4 lay 1.7-fold (0.24 log units) above the measured number; the measured number falls inside the stated range.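

In this assay, compound 4 shows that a second two-ring group at this position, on an aromatic carbon of the shared core, also brings the read-out off the ceiling, with isoquinolin-5-yl replacing the 1,3,5-trimethyl-1H-pyrazol-4-yl (an at least 3.9-fold lower number from compound 3 to compound 4 (0.59 log units; beyond the scatter)) or the 1,3-dimethyl-1H-pyrazol-4-yl (an at least 3.9-fold lower number from compound 2 to compound 4 (0.59 log units; beyond the scatter)). The group of compound 1 and isoquinolin-5-yl cannot be separated here (a 1.4-fold lower number from compound 1 to compound 4 (0.16 log units; within the scatter)), so a five-membered aromatic ring within the two-ring group is not needed to reach this level, and a six-membered aromatic ring of carbon only serves as well. The two steps from the pyrazoles give only a minimum size, because compound 2 and compound 3 carry limits rather than numbers: the limit of > 50000 nM in this assay, at which 2 of the 4 values shown sit.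

Among the compounds shown, only pyrazoles represent the single-ring groups, so it remains open whether the drop to the ceiling follows from losing the second ring or from the pyrazole itself, and a plain phenyl or pyridin-4-yl would address that. From the compounds shown here alone, the contribution of the ring nitrogen of isoquinolin-5-yl also remains open, and naphthalen-1-yl would test it directly.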